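The source may report more compounds than this note shows. Statements on the series, on what has been measured and on what is new or still open speak of the compounds shown alone.

Compound 1 `Cc1ccc(Cn2ccnc2NC(=O)[C@@H]2CN(C(C)(C)C)C[C@H]2c2ccc(F)cc2F)c(N2CCC(C(=O)O)CC2)c1` gives 318 nM in a functional assay for agonist activity at Melanocyte-stimulating hormone receptor (Homo sapiens), read by cAMP accumulation; a lower number here means that less compound is needed, a higher number that more compound is needed for the effect.
Compound 2 `CC(C)(C)N1C[C@@H](C(=O)Nc2nccn2Cc2ccc(Cl)cc2)[C@H](c2ccc(F)cc2F)C1` reaches only a limit in this assay, reported as > 10000 nM.
Compound 3 `CC(C)(C)N1C[C@@H](C(=O)Nc2ccccc2Cc2ccccc2)[C@H](c2ccc(F)cc2F)C1` also reaches only a limit in this assay, reported as > 10000 nM.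

All three compounds share the same core, and only compound 1 yields an actual number; it produces its effect at a far lower concentration than the others. Compound 2 stands at the ceiling of what this assay can resolve: the limit of > 10000 nM in this assay, at which 2 of the 3 values shown sit. Because compound 2 and compound 3 both sit at that limit, nothing can be said about their order relative to each other.

Compound 4 `CC(C)(C)N1C[C@@H](C(=O)Nc2nccn2Cc2ccccc2Cl)[C@H](c2ccc(F)cc2F)C1` keeps every atom of compound 2 and differs only in how they are joined: 2-chlorophenyl in place of 4-chlorophenyl on a saturated chain carbon bound to an aromatic nitrogen. Within the data shown here, no measured pair in this set changes the position of a substituent on this benzyl group, so there is no measured step to lean on. The two compounds carry the same atoms, and the chain between the chlorophenyl and the core is unchanged, so the expectation is for at most a modest shift, and most likely no step beyond the scatter, meaning compound 4 is expected to remain at or near the limit.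

Compound 4 is therefore estimated at 10000 nM, within a range of 3000 nM to 30000 nM, an expected step of a number no higher from compound 2 to compound 4 (the limit leaves the size open).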

Compound 4, half-maximal effective concentration: 1270 nM
Compound 4: the middle estimate sits 7.9-fold (0.90 log units) above what was measured; the measured number lies below the stated range.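

In this assay, placing the chlorine differently on the benzyl group, with 2-chlorophenyl in place of 4-chlorophenyl, gives an at least 7.8-fold lower number from compound 2 to compound 4 (0.89 log units; beyond the scatter). Among these compounds, this is the first measured step at this place in the molecule, and it shows that the result depends on where the chlorine sits on the aromatic ring, even though the two compounds carry the same atoms. The true size of the step stays unknown, because compound 2 stands at a limit and not at a number: the limit of > 10000 nM in this assay, at which 2 of the 4 values shown sit.

A single pair cannot show whether the chlorine itself matters or whether another group in its place would serve as well, as 2-methylphenyl, 2-methoxyphenyl or 2-fluorophenyl would test, and 3-chlorophenyl would complete the series of chlorine placements. A plain benzyl group with no substituent on the ring would also provide the missing baseline, showing whether the 2-chlorophenyl group lowers the number or the 4-chlorophenyl group raises it.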